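A few compounds are considered here, and "the series" means these few. Any claim that something is new, unique, unknown or untested is made for them only; others in the source may bear on it.

In a functional assay on MCF7 cells (Homo sapiens) for antiproliferative activity, read by MTT assay, with a stated time of 48 h (on this read-out higher numbers stand for weaker inhibition and lower numbers for stronger inhibition), three compounds built on one shared core have been measured. Compound 1 `CC(C)=CCC[C@]1(C)/C=C/[C@@H](OC(=O)C=C(C)C)[C@](C)(O)/C=C/C(=O)/C(CN2CCN(C)CC2)=C\C1` gives 550 nM, compound 2 `CC(C)=CCC[C@]1(C)/C=C/[C@@H](OC(=O)C=C(C)C)[C@](C)(O)/C=C/C(=O)/C(C[Si](C)(C)C(C)(C)C)=C\C1` gives 6040 nM, and compound 3 `CC(C)=CCC[C@]1(C)/C=C/[C@@H](OC(=O)C=C(C)C)[C@](C)(O)/C=C/C(=O)/C(C(=O)N(C)C)=C\C1` gives 3670 nM. This places compound 3 level with one neighbour and clear of the other: the step of a 1.6-fold lower number from compound 2 to compound 3 (0.22 log units; within the scatter) stays within the scatter, while the step of a 6.7-fold higher number from compound 1 to compound 3 (0.82 log units; beyond the scatter) goes beyond it.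

Among the compounds with values here, compound 4 `CCN(CC)C(=O)/C1=C/C[C@](C)(CCC=C(C)C)/C=C/[C@@H](OC(=O)C=C(C)C)[C@](C)(O)/C=C/C1=O` alters only one group of compound 3: diethylamino in place of dimethylamino on a carbonyl carbon. In other words, dimethylcarbamoyl becomes diethylcarbamoyl. Within the data shown here, no measured step makes this exact change. Among the measured compounds shown here, the large steps, an 11-fold higher number from compound 1 to compound 2 (1.04 log units; beyond the scatter) and the one to compound 3 already given, both start from compound 1 and remove its (4-methylpiperazin-1-yl)methyl group, which compound 3 and compound 4 both lack. For the measured compounds named here, the one step between compounds without that group is the small one, which stayed within the scatter. So no shift beyond the scatter is expected in this assay, and the estimated step is a 1.0-fold lower number from compound 3 to compound 4 (0.02 log units; within the scatter). For compound 4 the expected value is 3500 nM, with an estimated range from 1700 nM to 7200 nM.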

Compound 4, half-maximal inhibitory concentration: 12100 nM
The estimate for compound 4 lay 3.5-fold (0.54 log units) below the measured number; the whole stated range lies below it.
By their numbers in this assay, from the lowest: compound 1; then compounds 3, 2 and 4 (each within the scatter of the next, the first and the last beyond it).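

Among the amides, the size of the groups on the carbonyl carbon matters in this assay: going from dimethylamino to diethylamino gives a 3.3-fold higher number from compound 3 to compound 4 (0.52 log units; beyond the scatter), a shift that lies beyond the scatter even though the swap is small. With that change, the diethylcarbamoyl group ends up level with the silicon-bearing group of compound 2, as a 2.0-fold higher number from compound 2 to compound 4 (0.30 log units; within the scatter) stays within the scatter, and well away from the (4-methylpiperazin-1-yl)methyl group, as a 22-fold higher number from compound 1 to compound 4 (1.34 log units; beyond the scatter) shows. Nothing available explains why this small change in the amide has a clear effect on the number.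

Still open, going by these compounds, is how a dipropylamino group or a plain amino group on the same carbonyl carbon would compare, since two amides cannot establish a trend. It is also unknown whether a simpler amine, such as (dimethylamino)methyl, would match the (4-methylpiperazin-1-yl)methyl group of compound 1.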